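This account rests on a few compounds, and the source may have more. Where it says the series, first, only, none or still open, it means among the compounds named here.

Two compounds of this series carry numbers in a functional assay on PC-9 cells (Homo sapiens) for inhibition, read by MTT assay, with a stated time of 48 h, tested at 10 uM; on this read-out higher numbers stand for more inhibition at the one concentration tested (going by the name of the read-out) and lower numbers for less inhibition. Compound 1 `COc1ccc(F)cc1Nc1cc(NC(=O)Nc2c(Cl)cccc2Cl)ncn1` gives 85.5% in this assay. Compound 2 `CC(C)(C)c1ccc(Nc2cc(NC(=O)Nc3c(Cl)cccc3Cl)ncn2)cc1` gives 41.5% in this assay, the lower of the two numbers; the gap to compound 1 lies beyond the scatter. Among the compounds with values here, no step between measured compounds that differ in one place is available, so the two values show only that compound 1 and compound 2 are far apart, with more than one structural difference between them. Compound 3 `CCc1ccc(Nc2cc(NC(=O)Nc3c(Cl)cccc3Cl)ncn2)cc1` remains to be measured in this assay. It differs from compound 2 in one place: ethyl in place of tert-butyl on an aromatic carbon. The measured pair says nothing about this change, as it differs elsewhere too. The expected step is a number 2.5 percentage points higher from compound 2 to compound 3 (within the scatter), small and not beyond the scatter, in no firm direction. For compound 3 the estimated value is 44%, with a range from 20% to 68%.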

Compound 3, a percentage reported as inhibition, at one concentration (the size of the read-out at that concentration, not a potency): 70.1%
Estimate against measurement, compound 3: 26.1 percentage points below; the whole stated range lies below it.
By their numbers in this assay, from the lowest: compound 2; then compound 3; then compound 1.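

Working notes: the group on this aromatic carbon, para to a large group, has a clear bearing on the read-out in this assay: ethyl in place of tert-butyl gives a number 28.6 percentage points higher from compound 2 to compound 3 (beyond the scatter), the first reading in the series of a change in one place. The whole ring on the nitrogen also counts, as 4-ethylphenyl in place of 5-fluoro-2-methoxyphenyl gives a number 15.4 percentage points lower from compound 1 to compound 3 (beyond the scatter), so compound 3 does not close the gap to compound 1. Within the data shown here, nothing measured so far accounts for either step.

Among these compounds, with only two alkyl groups read at this carbon, a methyl, a longer chain such as propyl, or an amine there remains open. Also open, on these data alone, is how the methoxy and the fluorine of compound 1 each contribute, since they are read only together.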